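This account rests on a few compounds, and the source may have more. Where it says the series, first, only, none or still open, it means among the compounds named here.

Compound 1, with the structure `O=c1cc(CSC(=S)N2CCCC2)oc2ccccc12`, and compound 2, with the structure `O=c1cc(CSC(=S)N2CCCCC2)oc2ccccc12`, share one core and differ in a single place. In a functional assay on HEp-2 cells (Homo sapiens) for antiproliferative activity, read by MTT assay, with a stated time of 72 h (on this read-out higher numbers stand for weaker inhibition and lower numbers for stronger inhibition), compound 1 gives 9100 nM. In this assay compound 2 gives 12000 nM. The change between them is piperidin-1-yl in place of pyrrolidin-1-yl on a thiocarbonyl carbon, and the step it made was a 1.3-fold higher number from compound 1 to compound 2 (0.12 log units; within the scatter).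

Compound 3, with the structure `CCOC(=O)c1cc(=O)c2cc(CSC(=S)N3CCCC3)ccc2o1`, is built on a different core. The difference between the two cores is not broken down here. In this assay compound 3 gives 8900 nM, a number that sits close to those of compound 1 and compound 2.

Compound 4, with the structure `CCOC(=O)c1cc(=O)c2cc(CSC(=S)N3CCCCC3)ccc2o1`, has not yet been measured. It is related to compound 3 by piperidin-1-yl in place of pyrrolidin-1-yl on a thiocarbonyl carbon. Within the data shown here, this is the same change as the one from compound 1 to compound 2, made at the same kind of place, on a thiocarbonyl carbon whose other neighbour is sulfur, but on the core of compound 3 rather than that of compound 1.

The expectation for compound 4 rests on a single precedent: the step from compound 1 to compound 2 was small, because a 1.3-fold higher number from compound 1 to compound 2 (0.12 log units; within the scatter) lies within the usual scatter. If the new core carries this change the same way, the step from compound 3 to compound 4 is expected to be about a 1.2-fold higher number from compound 3 to compound 4 (0.09 log units; within the scatter). Compound 4 is therefore estimated to give about 11000 nM in this assay, with a likely range from 5500 nM to 22000 nM. Whether the two cores respond alike to this change is exactly what the coming measurement will show.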

Compound 4, half-maximal inhibitory concentration: 3400 nM
Beside the measured number, compound 4's estimate is 3.2-fold (0.51 log units) above it, and the stated range ends above it.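

In this assay, the same swap of pyrrolidin-1-yl for piperidin-1-yl on the thiocarbonyl carbon gave a 2.6-fold lower number from compound 3 to compound 4 (0.42 log units; beyond the scatter), a step that can be told apart from the usual noise, whereas on the core of compound 1 it made no such difference. The two steps do not match, so in this series the effect of this change did not carry over from one core to the other: the same change on two cores in this assay, a 1.3-fold higher number (0.12 log units; within the scatter) from compound 1 to compound 2 and a 2.6-fold lower number (0.42 log units; beyond the scatter) from compound 3 to compound 4, 3.5-fold (0.54 log units) apart, beyond the scatter of two such steps. Among these compounds, this shows that the core can matter to the outcome of the swap, but it rests on only two pairs of compounds, and it does not show which feature of the two cores is responsible, how the change produces the step, or whether the same split would appear on any third core.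

The compounds shown leave open whether another amine on the thiocarbonyl carbon, such as morpholine or dimethylamine, would also separate the two cores in this way. They also leave open whether the lower number of compound 4 would survive replacing the ethyl ester with a carboxylic acid or an amide.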